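This account rests on a few compounds, and the source may have more. Where it says the series, first, only, none or still open, it means among the compounds named here.

Working notes on the series.

Compound 1 `CCCCc1ccc2[nH]c(-c3ccc(OC)cc3)c(C=O)c2c1` is the reference point. In a functional assay on MDA-MB-231 cells (Homo sapiens) for antiproliferative activity, with a stated time of 4 days (on this read-out lower numbers stand for stronger inhibition and higher numbers for weaker inhibition), compound 1 gives 6.7 nM. Compound 2 `CCCCc1ccc2[nH]c(-c3ccc(C(F)(F)F)cc3)c(C=O)c2c1` differs from it by one change, (trifluoromethyl in place of methoxy on an aromatic carbon), and in this assay compound 2 gives 33 nM; the step is a 4.9-fold higher number from compound 1 to compound 2 (0.69 log units; beyond the scatter).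

Compound 3 `CCCCc1ccc2[nH]c(-c3ccc(OC)cc3)c(/C=N/NC(=O)c3cccnc3)c2c1` carries a different core; the difference between the core of compound 1 and the core of compound 3 is not broken down here. In this assay compound 3 gives 35 nM, and the values of compound 3 and compound 2 lie within the scatter of each other.

Compound 4 `CCCCc1ccc2[nH]c(-c3ccc(C(F)(F)F)cc3)c(/C=N/NC(=O)c3cccnc3)c2c1` differs from compound 3 by trifluoromethyl in place of methoxy on an aromatic carbon, the same change that was seen from compound 1 to compound 2, occurring twice among these compounds. Among the measured compounds shown here, the expectation for compound 4 rests on the single earlier instance, because a 4.9-fold higher number from compound 1 to compound 2 (0.69 log units; beyond the scatter) was the result on the core of compound 1 and whether it transfers to the core of compound 3 is not known. The step expected from compound 3 to compound 4 is estimated as a 4.3-fold higher number from compound 3 to compound 4 (0.63 log units; beyond the scatter). Compound 4 is thus estimated at 150 nM, with a range from 50 nM to 500 nM.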

Compound 4, half-maximal inhibitory concentration: 97 nM
The estimate for compound 4 lay 1.5-fold (0.19 log units) above the measured number; low and high end bracket the measured number.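

The 4-methoxyphenyl to 4-(trifluoromethyl)phenyl change gives a higher number on both cores in this assay, and on the core of compound 3 the step is (a 2.8-fold higher number from compound 3 to compound 4 (0.44 log units; beyond the scatter)). This shows that the direction carried over in these two instances, but two cores do not show that it would carry to a third, and they fix no exact size for the step. The sizes themselves cannot be told apart: the same change on two cores in this assay, a 4.9-fold higher number (0.69 log units; beyond the scatter) from compound 1 to compound 2 and a 2.8-fold higher number (0.44 log units; beyond the scatter) from compound 3 to compound 4, 1.8-fold (0.25 log units) apart, within the scatter of two such steps

The core difference, read with trifluoromethyl in place on both compounds, is a separate step (a 2.9-fold higher number from compound 2 to compound 4 (0.47 log units; beyond the scatter)), and it stands beyond the scatter. On these data alone, whether an amine or a carboxylic acid at the same place on the aromatic ring would follow methoxy or trifluoromethyl stays open, as does the outcome of a longer chain in place of the butyl chain. The compounds shown also leave open whether the same order holds in any read-out other than this assay.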